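Fluorine at a new ring position on compound 1

The compounds below may be only part of what the source reports. "The series", "measured", "known", "first", "only" and "open" are said of these compounds alone.

Three compounds have been measured in a functional assay on HEK293 cells for agonist activity at Free fatty acid receptor 1 (Homo sapiens), read by fluorescence and calcium flux; on this read-out lower numbers stand for an effect already at smaller amounts and higher numbers for an effect only at larger amounts of compound:
Compound 1 `CC#CC(CC(=O)O)c1ccc(OCc2ccc(C(=O)N3CCN(c4ccccc4)CC3)s2)cc1` gives 72 nM.
Compound 2 `CC#CC(CC(=O)O)c1ccc(OCc2ccc(C(=O)N3CCN(c4ccc(Cl)cc4)CC3)s2)cc1` gives 133 nM.
Compound 3 `CC#CC(CC(=O)O)c1ccc(OCc2ccc(C(=O)N3CCN(c4cccc(F)c4)CC3)s2)cc1` gives 97 nM.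

All three share one core and differ only on the phenyl ring that sits on the ring nitrogen. Compound 1 carries the plain phenyl; the others carry one halogen on it. The steps away from compound 1 are a 1.8-fold higher number from compound 1 to compound 2 (0.27 log units; within the scatter) and a 1.3-fold higher number from compound 1 to compound 3 (0.13 log units; within the scatter), so compound 1 stands together with compound 2 and compound 3 inside one band of scatter, and no ordering among the three can be read from these numbers.

Compound 4 `CC#CC(CC(=O)O)c1ccc(OCc2ccc(C(=O)N3CCN(c4ccccc4F)CC3)s2)cc1` is the next member. Against compound 1 the change is fluoro in place of hydrogen on an aromatic carbon. The two halogen steps already seen bear directly on this: a fluoro at a different aromatic carbon gave a 1.3-fold higher number from compound 1 to compound 3 (0.13 log units; within the scatter), and a chloro gave a 1.8-fold higher number from compound 1 to compound 2 (0.27 log units; within the scatter), both within the scatter. A single fluoro at yet another carbon of the same ring is therefore expected to move the number little, if at all: the expected step is a 1.3-fold higher number from compound 1 to compound 4 (0.10 log units; within the scatter), which would stay within the scatter. Compound 4 is accordingly estimated at 90 nM, with a range from 45 nM to 180 nM.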

Compound 4, half-maximal effective concentration: 113 nM
Beside the measured number, compound 4's estimate is 1.3-fold (0.10 log units) below it, within the range that was stated.
By their numbers in this assay, from the lowest: compounds 1, 3, 4 and 2 (each within the scatter of the next).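

Among the compounds shown here, the fluoro of compound 4 sits ortho to a large group, a place on the ring that none of the earlier compounds occupied, and in this assay putting it there gives a 1.6-fold higher number from compound 1 to compound 4 (0.20 log units; within the scatter) as the step. Set against the earlier halogens, shifting the single fluoro to this carbon gives a 1.2-fold higher number from compound 3 to compound 4 (0.07 log units; within the scatter) and exchanging the 4-chlorophenyl for 2-fluorophenyl gives a 1.2-fold lower number from compound 2 to compound 4 (0.07 log units; within the scatter) so neither comparison separates the new compound from the earlier ones. The new information is that a single fluoro at this further ring position also leaves the number inside the same band, and the four compounds still cannot be put in any order.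

On these data alone, whether a methoxy group, a trifluoromethyl group, an amine or a second fluoro on this ring would carry the number beyond the scatter stays open. No measurement is available that could explain why the four numbers lie so close together.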